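Swapping a benzothiazole for a benzofuran on the aryl tail

The compounds below may be only part of what the source reports. "The series", "measured", "known", "first", "only" and "open" are said of these compounds alone.

Measured so far:
compound 1 `O=C(O)CCCSCCN1C(=O)CC[C@@H]1/C=C/[C@@H](O)Cc1cccc(-c2ccc3[nH]ccc3c2)c1` — 85 nM
compound 2 `O=C(O)CCCSCCN1C(=O)CC[C@@H]1/C=C/[C@@H](O)Cc1cccc(-c2nc3ccccc3s2)c1` — 3.2 nM

In a functional assay on CHO cells for agonist activity at prostaglandin E2 receptor EP4 subtype (Rattus norvegicus), read by cAMP accumulation and immunoassay, with a stated time of 10 min (a lower number here means that less compound is needed, a higher number that more compound is needed for the effect), compound 2 gives the lowest of the two numbers; its nearest neighbour is compound 1, with a 27-fold lower number from compound 1 to compound 2 (1.42 log units; beyond the scatter). Compound 3 `O=C(O)CCCSCCN1C(=O)CC[C@@H]1/C=C/[C@@H](O)Cc1cccc(-c2cc3ccccc3o2)c1` differs from compound 2 by 1-benzofuran-2-yl in place of 1,3-benzothiazol-2-yl on an aromatic carbon. Going by the values given here, the one measured step does not involve a benzofuran, so it only shows that the two-ring group at this position matters a great deal. With the attachment point and ring size kept, compound 3 is expected to stay close to compound 2, with a 1.9-fold higher number from compound 2 to compound 3 (0.27 log units; within the scatter). Compound 3 is therefore estimated at 6 nM, in the range 1.5 nM to 25 nM.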

Compound 3, half-maximal effective concentration: 7 nM
Compound 3: middle estimate off by 1.2-fold (0.07 log units), on the low side; the range from low to high includes it.
By their numbers in this assay, from the lowest: compound 2; then compound 3; then compound 1.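

Replacing 1,3-benzothiazol-2-yl with 1-benzofuran-2-yl gives a 2.2-fold higher number from compound 2 to compound 3 (0.34 log units; beyond the scatter) in this assay, so this position tolerates losing the ring nitrogen and sulfur at only a modest cost. The 1-benzofuran-2-yl group also retains a large advantage over 1H-indol-5-yl, with a 12-fold lower number from compound 1 to compound 3 (1.08 log units; beyond the scatter), showing that this advantage does not belong to the benzothiazole alone. No evidence here explains either step. Still open, as far as these compounds go, is how a 1,3-benzoxazol-2-yl group, with ring nitrogen and oxygen together, would behave. A 1H-indol-2-yl group would also separate the effect of the attachment point from that of the ring atoms.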